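Replacing a morpholine amide with a five-membered unsaturated ring

The compounds below may be only part of what the source reports. "The series", "measured", "known", "first", "only" and "open" are said of these compounds alone.

The series begins with compound 1 `N=C(N)c1cccc(OCC(=O)Nc2ccc(C(=O)N3CCCCC3)cc2)c1`. In an assay on isolated protein for inhibition of serine protease 1 (Homo sapiens) (a lower number here means a stronger inhibitor, a higher number a weaker inhibitor), compound 1 is reported only as a limit, > 10000 nM. Compound 2 `N=C(N)c1cccc(OCC(=O)Nc2ccc(C(=O)N3CCOCC3)cc2)c1` carries a morpholin-4-yl group in place of the piperidin-1-yl group on the carbonyl carbon. In this assay compound 2 likewise is reported only as a limit, > 10000 nM. The step that the two limits leave unreadable from compound 1 to compound 2 therefore cannot be read, since both ends sit at the limit of > 10000 nM in this assay, at which 2 of the 2 values shown sit; compound 2 stands at that limit and nowhere more precisely.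

Compound 3 `N=C(N)c1cccc(OCC(=O)Nc2ccc(C(=O)N3CC=CC3)cc2)c1` differs from compound 2 by a group of 5 heavy atoms (4 carbon, 1 nitrogen; one five-membered non-aromatic ring with 1 hetero atom) in place of a group of 6 heavy atoms (4 carbon, 1 nitrogen, 1 oxygen; one six-membered non-aromatic ring with 2 hetero atoms), on a carbonyl carbon. Only the step from compound 1 to compound 2 touches this carbonyl position, and its size is not readable, so the shown data give no measure of how a change at this place moves this assay. With compound 2 at its limit, the expectation is that compound 3 also remains weak, an estimated step that the limit leaves unreadable from compound 2 to compound 3. Compound 3 is therefore expected to give about 15000 nM in this assay, with a range from 3000 nM to 60000 nM, most likely reported again as a limit.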

Compound 3, half-maximal inhibitory concentration: 875 nM
For compound 3 the middle estimate is 17-fold (1.23 log units) above the measured one, and the stated range ends above it.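

Compound 3 shows that a change on this carbonyl carbon can move this assay, which the earlier pair could not show, as the step between compound 1 and compound 2 cannot be read and both of those compounds stand at a limit: the limit of > 10000 nM in this assay, at which 2 of the 3 values shown sit.

The five-membered ring with its double bond gives an at least 11-fold lower number from compound 2 to compound 3 (1.05 log units; beyond the scatter) when it replaces morpholin-4-yl, and an at least 11-fold lower number from compound 1 to compound 3 (1.05 log units; beyond the scatter) when it replaces piperidin-1-yl, so the same large change appears against both six-membered rings. Compound 1 has no ring oxygen and still stands at the limit, so losing that oxygen alone does not bring a readable value among these compounds.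

The compounds shown leave ring size and the double bond changed together, so they do not say which of the two goes with the step, and a pyrrolidin-1-yl group, the same five-membered ring without the double bond, would be needed to separate them. Going by these compounds, how far this position tolerates other groups also stays open, for instance a smaller azetidin-1-yl ring or an open-chain dimethylamino group on the same carbonyl carbon.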